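A tert-butyl for trifluoromethyl swap on the aryl ring

This account rests on a few compounds, and the source may have more. Where it says the series, first, only, none or still open, it means among the compounds named here.

The compounds share a carboxylic acid core, shown in compound 1 `Cc1cc(C(=O)O)c(C)n1C`. In an assay on cells for inhibition of Palmitoleoyl-protein carboxylesterase NOTUM variant C330S (Homo sapiens), read by fluorescence, with a stated time of 40 min (on this read-out lower numbers stand for stronger inhibition and higher numbers for weaker inhibition), compound 1 gives only a limit, > 100000 nM, as recorded in the limit of > 100000 nM in this assay, at which 1 of the 3 values shown sits. Compound 2 `Cc1cc(C(=O)O)c(C)n1-c1ccc(Cl)c(C(F)(F)F)c1` gives 2100 nM in this assay. Among the measured compounds shown here, compound 3 `Cc1cc(C(=O)O)c(C)n1-c1cccc(C(F)(F)F)c1` gives 1500 nM in this assay and holds the lowest of the two numbers, the only measured step being a 1.4-fold lower number from compound 2 to compound 3 (0.15 log units; within the scatter). Compound 4 `Cc1cc(C(=O)O)c(C)n1-c1cccc(C(C)(C)C)c1` differs from compound 3 by tert-butyl in place of trifluoromethyl on an aromatic carbon. For the measured compounds named here, that measured step concerned a different group and stayed within the scatter, so no measured step bears directly on this change. The step to compound 4 is expected to be no change at the digits printed from compound 3 to compound 4 (within the scatter), no more than the scatter. The estimate for compound 4 is 1500 nM, with a range from 500 nM to 5000 nM.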

Compound 4, half-maximal inhibitory concentration: 460 nM
The estimate for compound 4 lay 3.3-fold (0.51 log units) above the measured number, and the stated range ends above it.
By their numbers in this assay, from the lowest: compound 4; then compounds 3 and 2 (each within the scatter of the next). At a limit, above all of these: compound 1.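

In this assay, the aromatic carbon carrying trifluoromethyl proves sensitive to what sits there: tert-butyl in its place gives a 3.3-fold lower number from compound 3 to compound 4 (0.51 log units; beyond the scatter) and this step lies beyond the scatter, unlike the earlier step that removed chloro. The two groups match in heavy atoms, hydrogen-bond donors and hydrogen-bond acceptors, so those counts do not separate them. Nothing measured here accounts for the step. On these data alone, whether isopropyl, cyclopropyl or an amine on this carbon would follow tert-butyl stays open, as does the effect of chloro on a ring bearing tert-butyl.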